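Moving the halogen on the triazole-bound phenyl ring

A few compounds are considered here, and "the series" means these few. Any claim that something is new, unique, unknown or untested is made for them only; others in the source may bear on it.

Compound 1, `C/C(=C\CC/C(C)=C/CC[C@@H]1[C@@]2(C)CCC(=O)C(C)(C)[C@H]2CC[C@@]1(C)O)CC/C=C(\C)C(=O)OCc1cn(-c2ccccc2Cl)nn1`, gives > 150000 nM in an ADME assay on L132 cells (Homo sapiens) for cytotoxicity, read by MTT assay, with a stated time of 48 h (on this read-out lower numbers stand for stronger inhibition and higher numbers for weaker inhibition), which is a limit of the assay rather than a number.
Compound 2, `C/C(=C\CC/C(C)=C/CC[C@@H]1[C@@]2(C)CCC(=O)C(C)(C)[C@H]2CC[C@@]1(C)O)CC/C=C(\C)C(=O)OCc1cn(-c2ccccc2C(F)(F)F)nn1`, gives > 150000 nM in this assay, again a limit rather than a number.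
Compound 3, `C/C(=C\CC/C(C)=C/CC[C@@H]1[C@@]2(C)CCC(=O)C(C)(C)[C@H]2CC[C@@]1(C)O)CC/C=C(\C)C(=O)OCc1cn(-c2cccc(Cl)c2)nn1`, gives 94200 nM in this assay.

Among the measured compounds shown here, compound 3 therefore holds the only actual number among the three; the other two sit at the limit of > 150000 nM in this assay, at which 2 of the 3 values shown sit. Compound 4, `C/C(=C\CC/C(C)=C/CC[C@@H]1[C@@]2(C)CCC(=O)C(C)(C)[C@H]2CC[C@@]1(C)O)CC/C=C(\C)C(=O)OCc1cn(-c2ccccc2Br)nn1`, has not yet been measured. It differs from compound 3 in this way: 2-bromophenyl in place of 3-chlorophenyl on an aromatic nitrogen. For the measured compounds named here, two measured steps touch the same spot. Going an at least 1.5-fold lower number from compound 1 to compound 3 (0.20 log units; that floor lies within the scatter) and going an at least 1.5-fold lower number from compound 2 to compound 3 (0.20 log units; that floor lies within the scatter), both moving a substituent from the position next to the ring nitrogen out to the 3-position, gave a lower number, though each floor lies within the scatter. Compound 4 moves the halogen back toward the position held in compound 1 and compound 2, so the number is expected to rise again, most likely to the limit. The estimated step is a 1.5-fold higher number from compound 3 to compound 4 (0.17 log units; within the scatter), and compound 4 is expected to give about 140000 nM, between 70000 nM and 300000 nM.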

Compound 4, half-maximal inhibitory concentration: > 150000 nM
Compound 4 ended at the assay's limit; the forecaster's own chance of this, stated with the estimate: 60%; middle value at least 1.0-fold (0.02 log units) away from the limit.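

Bromo now joins chloro and trifluoromethyl: in this assay, the 2-bromophenyl group of compound 4 gives a limit rather than a number, as the 2-chlorophenyl group of compound 1 and the 2-(trifluoromethyl)phenyl group of compound 2 do, so three different substituents on this ring share one outcome: the limit of > 150000 nM in this assay, at which 3 of the 4 values shown sit.

Among the compounds shown, only the 3-chlorophenyl group of compound 3 gives an actual number. Among the compounds shown here, the one readable step is an at least 1.5-fold higher number from compound 3 to compound 4 (0.20 log units; that floor lies within the scatter), while the steps linking compound 4 to compound 1 and compound 2 cannot be read.

Still open, on these data alone, is what a plain phenyl group, or an amine or methoxy group on that ring, would give here. As far as these compounds go, how far compound 1, compound 2 and compound 4 lie beyond their shared limit, and whether they differ from one another, also remains unknown.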